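The source may hold more compounds than are shown below. What is called first, only, known or untested is meant among the compounds shown, and "the series" means these compounds.

In a functional assay on cells (Homo sapiens) for cytotoxicity, read by resazurin assay, with a stated time of 72 h (a lower number here means a stronger inhibitor, a higher number a weaker inhibitor), compound 2 `COc1cc(/C=C/C(=O)OCCCCCO[N+](=O)[O-])ccc1O` gives 24900 nM, and compound 3 `COc1cc(/C=C/C(=O)OCCCO[N+](=O)[O-])ccc1O` gives 39400 nM. These two numbers stand level, with a 1.6-fold higher number from compound 2 to compound 3 (0.20 log units; within the scatter). Compound 1 `O=C(/C=C/c1ccc(OCCCCCO[N+](=O)[O-])c(O)c1)OCCCCCO[N+](=O)[O-]` gives only a limit of the assay, > 50000 nM. Compound 4 `COc1cc(/C=C/C(=O)OCCCCCO[N+](=O)[O-])ccc1OCCCCCO[N+](=O)[O-]` departs from compound 2 by one change, 5-(nitrooxy)pentyl in place of hydrogen on an oxygen on an aromatic ring. Going by the values given here, no measured step makes this change, and the one measured step concerns the chain on the other side of the molecule. The nearest guide is compound 1, which also bears this chain on such an oxygen and stands at the limit of > 50000 nM. A move towards a weaker number in this assay is therefore expected, the expected step being a 2.2-fold higher number from compound 2 to compound 4 (0.34 log units; beyond the scatter). For compound 4 the estimated value is 55000 nM, with an expected range of 28000 nM to 110000 nM.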

Compound 4, half-maximal inhibitory concentration: > 50000 nM
Compound 4 gave a limit, no number; the forecaster's own chance of this, stated with the estimate: 55%; the middle value lies beyond the limit too.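

In this assay, the change from hydroxy to (5-(nitrooxy)pentyl)oxy on the aromatic ring can now be read directly, as an at least 2.0-fold higher number from compound 2 to compound 4 (0.30 log units; that floor lies within the scatter); only that floor is known, so the true size of the step stays hidden. Compound 4 gives a limit of the assay, not a number, and shares it with compound 1: the limit of > 50000 nM in this assay, at which 2 of the 4 values shown sit. The step between these two limit compounds cannot be read.

On these data alone, it remains open how far compound 4 lies past its limit. As far as these compounds go, it is also open whether a shorter chain, or an amine in place of the nitrooxy end, would change the reading at this oxygen.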